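A few compounds are considered here, and "the series" means these few. Any claim that something is new, unique, unknown or untested is made for them only; others in the source may bear on it.

In an in vivo ADME assay on the whole organism (strain BALB/c) for pharmacokinetics, with Mus musculus as the target, read by LC-MS, at a dose of 5 mg/kg by the oral route (a higher number here means that a larger share of the oral dose reaches the circulation, a lower number that a smaller share of the oral dose reaches the circulation), compound 3 `CS(=O)(=O)c1ccc(Cl)c(C#Cc2cc(Cl)ccc2OCC(=O)O)c1` reaches 141% and stands highest of the three compounds measured, beyond the scatter from both others. Compound 1 `CN(C)S(=O)(=O)c1ccc(F)c(C#Cc2cc(Cl)ccc2OCC(=O)O)c1` gives 58% and compound 2 `CCCS(=O)(=O)c1ccc(F)c(C#Cc2cc(Cl)ccc2OCC(=O)O)c1` gives 63% in this assay and both carry fluoro where compound 3 carries chloro, though they also differ from it at the sulfonyl sulfur. Compound 4 `CS(=O)(=O)c1ccc(F)c(C#Cc2cc(Cl)ccc2OCC(=O)O)c1` shares the methylsulfonyl group of compound 3 and departs from it by fluoro in place of chloro on an aromatic carbon with fluoro in place of chloro on an aromatic carbon. Among the measured compounds shown here, no measured step covers this exchange on its own. For the measured compounds named here, the one measured step, a number 5 percentage points higher from compound 1 to compound 2 (within the scatter), lies at the sulfonyl sulfur and stays within the scatter, so the change there counts for little in this comparison. A clear fall is therefore expected, with an estimated a number 66 percentage points lower from compound 3 to compound 4 (beyond the scatter) in this assay that remains uncertain in size. The expected value for compound 4 is 75% with an estimated range from 45% to 115%.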

Compound 4, oral bioavailability: 24%
Compound 4: middle estimate off by 51 percentage points, on the high side; measured number below the stated range.
By their numbers in this assay, from the lowest: compound 4; then compounds 1 and 2 (each within the scatter of the next); then compound 3.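

In this assay, the exchange of chloro for fluoro, on an aromatic carbon ortho to a large group and para to a methylsulfonyl group, now stands alone, and it gives a number 117 percentage points lower from compound 3 to compound 4 (beyond the scatter), so this single atom carries a large effect. With fluoro in this place, the group on the sulfonyl sulfur also matters, which the step between the two earlier fluoro compounds, a number 5 percentage points higher from compound 1 to compound 2 (within the scatter), did not show: methyl in place of propyl's ethyl extension gives a number 39 percentage points lower from compound 2 to compound 4 (beyond the scatter), and methyl in place of dimethylamino gives a number 34 percentage points lower from compound 1 to compound 4 (beyond the scatter). No measurement here bears on why either change acts as it does. The compounds shown leave open whether bromo, methyl or hydrogen at this aromatic carbon would follow chloro or fluoro. They also leave open whether chloro would raise the number with propyl or dimethylamino on the sulfonyl sulfur.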